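Urea series: aryl swap on the shared core

The source may report more compounds than this note shows. Statements on the series, on what has been measured and on what is new or still open speak of the compounds shown alone.

Among the compounds with values here, compound 1 `O=C(Nc1cccc(C(F)(F)F)c1)N[C@H]1CC[C@H](O)CC1` is the first entry. In a functional assay on CRL2813 cells (Homo sapiens) for cytotoxicity, read by sulforhodamine B assay, with a stated time of 5 days (on this read-out higher numbers stand for weaker inhibition and lower numbers for stronger inhibition), compound 1 gives > 20000 nM, which is a limit of the assay and not a number. Compound 2 `O=C(Nc1ccc([N+](=O)[O-])cc1)N[C@H]1CC[C@H](Oc2ccc(F)cc2)CC1` shares the urea but carries a different substituent on the saturated ring and a 4-nitrophenyl on the amide-type nitrogen. In this assay, within the data shown here, compound 2 gives 2300 nM; this is the only number in the set so far, so compound 2 stands alone as the sole measured point against which a new analogue can be read. The mark the limit of > 20000 nM in this assay, at which 1 of the 2 values shown sits, is the only other reference on the scale.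

Compound 3 `CSc1cccc(NC(=O)N[C@H]2CC[C@H](Oc3ccc(F)cc3)CC2)c1` keeps the core of compound 2 and changes the aryl on the urea: 3-(methylsulfanyl)phenyl in place of 4-nitrophenyl on an amide-type nitrogen. Among the measured compounds shown here, no measured pair in the set shares this change, so there is no step to lean on. The expected step in this assay is a 1.7-fold higher number from compound 2 to compound 3 (0.24 log units; within the scatter), a modest weakening that may not exceed the scatter. Compound 3 is estimated at 4000 nM, with the range running from 1000 nM to 20000 nM.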

Compound 3, half-maximal inhibitory concentration: 11100 nM
The estimate for compound 3 lay 2.8-fold (0.44 log units) below the measured number; measured number inside the range.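

In this assay, the aryl on the amide-type nitrogen now has a readable effect of its own: with the rest of the structure held fixed, 3-(methylsulfanyl)phenyl in place of 4-nitrophenyl gives a 4.8-fold higher number from compound 2 to compound 3 (0.68 log units; beyond the scatter). Within the data shown here, compound 1 and compound 2 differ in more than one place, so this is the first change that can be assigned to a single site, and it shows that this site alone can move the read-out beyond the usual scatter, here towards weaker inhibition. Nothing measured here accounts for the size or direction of this step.

The swap replaces the substituent and also changes its printed position on the phenyl ring, so this single pair cannot show whether the step follows the loss of the nitro group, the arrival of the methylsulfanyl group, or the change of position. Also open, going by these compounds, is how an aryl bearing an amine or a carboxylic acid would read on this nitrogen, and whether the same aryl swap gives a similar step on the core of compound 1.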